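From pentylamino to allylamino: what to expect

The source may report more compounds than this note shows. Statements on the series, on what has been measured and on what is new or still open speak of the compounds shown alone.

Of the compounds shown here, two with a shared core have been measured in a functional assay (Nicotiana tabacum); on this read-out lower numbers stand for stronger inhibition and higher numbers for weaker inhibition. Compound 1 `CNc1nc(SC)nc2ncccc12` gives 2920 nM in this assay, and compound 2 `CCCCCNc1nc(SC)nc2ncccc12` gives 650 nM in this assay. Among the compounds with values here, compound 2 therefore holds the lowest of the two numbers seen so far, with compound 1 as its only neighbour. Within the data shown here, the single step between them, a 4.5-fold lower number from compound 1 to compound 2 (0.65 log units; beyond the scatter), shows that butyl in place of hydrogen on a saturated chain carbon bound to a nitrogen on an aromatic ring moved the number down.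

Compound 3 `C=CCNc1nc(SC)nc2ncccc12` has not yet been measured in this assay. It differs from compound 2 by vinyl in place of butyl on a saturated chain carbon bound to a nitrogen on an aromatic ring. Among the measured compounds shown here, the only step that bears on this is the one from compound 1 to compound 2, which is modest but beyond the scatter. Since vinyl in place of butyl takes the chain part of the way back toward hydrogen, compound 3 is expected to sit between compound 1 and compound 2, with a step of a 2.0-fold higher number from compound 2 to compound 3 (0.30 log units; within the scatter) upward from compound 2. Compound 3 is estimated at 1300 nM in this assay, within a range of 500 nM to 3200 nM.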

Compound 3, half-maximal inhibitory concentration: 400 nM
Compound 3: the middle estimate sits 3.3-fold (0.51 log units) above what was measured; the whole stated range lies above it.
By their numbers in this assay, from the lowest: compounds 3 and 2 (each within the scatter of the next); then compound 1.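

In this assay the change from pentylamino to allylamino gives a 1.6-fold lower number from compound 2 to compound 3 (0.21 log units; within the scatter) and so lies within the scatter, which means the two chains cannot be told apart here. The shorter allyl chain therefore does not give back what the pentyl chain gained over compound 1, and the full pentyl length is not needed to reach this level. The other new step, a 7.3-fold lower number from compound 1 to compound 3 (0.86 log units; beyond the scatter) in the same assay, is beyond the scatter, so on a saturated chain carbon bound to a nitrogen on an aromatic ring, both allyl and pentyl set their compounds apart from compound 1; no measurement is at hand that could explain this.

The compounds shown leave open whether the double bond of the allyl group matters at all, since only a saturated propyl chain on the same nitrogen would separate its part from that of chain length. They also leave open how far this tolerance extends, for instance to a benzyl group, a cyclopropylmethyl group or a chain ending in a hydroxyl.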